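The compounds below may be only part of what the source reports. "The series", "measured", "known", "first", "only" and "open" are said of these compounds alone.

Compound 1 `Cn1c([N+](=O)[O-])cnc1C(=O)N1CCCC1`: > 100000 nM
Compound 2 `CN(C)C(=O)c1ncc([N+](=O)[O-])[nH]1`: > 100000 nM

In a toxicity assay on HEK293 cells (Homo sapiens) for inhibition, read by resazurin assay, with a stated time of 24 h (on this read-out lower numbers stand for higher toxicity in this test and higher numbers for lower toxicity in this test), compound 2 gives > 100000 nM, which is a limit of the assay and not a number. Both measured compounds stand at the limit of > 100000 nM in this assay, at which 2 of the 2 values shown sit. Compound 3 `O=C(c1ncc([N+](=O)[O-])[nH]1)N1CCCC1` has pyrrolidin-1-yl in place of dimethylamino on a carbonyl carbon. Within the data shown here, no measured step shows what this change does. Compound 1 also carries pyrrolidin-1-yl on a carbonyl carbon, and its reading of > 100000 nM is likewise a limit. The expected size of a number no higher from compound 2 to compound 3 (the limit leaves the size open) is therefore none beyond the scatter, in either direction. For compound 3 the estimate is 100000 nM, with an expected range of 40000 nM to 250000 nM.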

Compound 3, half-maximal cytotoxic concentration: > 100000 nM
Compound 3 gave a limit, no number; the forecaster's own chance of this, stated with the estimate: 85%; the middle value lies on the limit itself.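

No step can be read among compound 1, compound 2 and compound 3, because each reading is a limit of the assay and not a number: the limit of > 100000 nM in this assay, at which 3 of the 3 values shown sit.

Still open, as far as these compounds go, is whether swapping dimethylamino for pyrrolidin-1-yl on a carbonyl carbon, or methyl for hydrogen on an aromatic nitrogen, changes toxicity in this test.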